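The compounds below may be only part of what the source reports. "The series", "measured", "known", "first", "only" and "open" are said of these compounds alone.

Measured compounds in hand:

- compound 1, `COc1cccc(/C=C2\CCC/C(=C\c3cccc(OC)c3OC)C2=O)c1`: 9900 nM in a functional assay on HT-1080 cells (Homo sapiens) for cytotoxicity, read by MTT assay, with a stated time of 72 h; a higher number here means a weaker inhibitor, a lower number a stronger inhibitor
- compound 2, `COc1cc(/C=C2\CCC/C(=C\c3cccc(OC)c3OC)C2=O)cc(OC)c1`: 4500 nM
- compound 3, `COc1ccc(/C=C2\CCC/C(=C\c3ccc(OC)c(OC)c3)C2=O)cc1`: 7200 nM

Compound 1 and compound 2 are a matched pair; methoxy in place of hydrogen on an aromatic carbon gave a 2.2-fold lower number from compound 1 to compound 2 (0.34 log units; beyond the scatter). Compound 3 stands near the other two: its value and that of compound 1 lie within the scatter of each other, and the same holds for compound 3 against compound 2, so no order among these three is claimed. The core of compound 3 is built from the same atoms as the core of compound 1, joined differently; the difference between the two cores is not broken down here.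

Compound 4, `COc1ccc(/C=C2\CCC/C(=C\c3ccc(OC)c(OC)c3)C2=O)cc1OC`, is the next member and has not yet been measured. It differs from compound 3 by methoxy in place of hydrogen on an aromatic carbon. For the measured compounds named here, this is the same kind of change as the one from compound 1 to compound 2, but not the same: in compound 2 the entering methoxy sits meta to a large group and meta to a methoxy group, whereas in compound 4 it sits ortho to a methoxy group and meta to a large group. Going by the values given here, only one prior instance of the change exists, on a core that is not identical, so the expectation is a step of the same direction, taken with caution.

The step from compound 3 to compound 4 in this assay is expected to be a 2.0-fold lower number from compound 3 to compound 4 (0.30 log units; within the scatter), because the same kind of change gave a 2.2-fold lower number from compound 1 to compound 2 (0.34 log units; beyond the scatter). Starting from the value of compound 3, 7200 nM, compound 4 is estimated at 3600 nM. The expected range for compound 4 runs from 1600 nM to 8000 nM.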

Compound 4, half-maximal inhibitory concentration: 3000 nM
Beside the measured number, compound 4's estimate is 1.2-fold (0.08 log units) above it; the range from low to high includes it.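

In this assay, methoxy in place of hydrogen on an aromatic carbon gave a 2.4-fold lower number from compound 3 to compound 4 (0.38 log units; beyond the scatter), and this step matches the earlier one: the same change on two cores in this assay, a 2.2-fold lower number (0.34 log units; beyond the scatter) from compound 1 to compound 2 and a 2.4-fold lower number (0.38 log units; beyond the scatter) from compound 3 to compound 4, 1.1-fold (0.04 log units) apart, within the scatter of two such steps

Across these two cores, the change therefore carries over in direction and in size, even though in compound 4 the entering methoxy sits ortho to a methoxy group and meta to a large group, a different setting from the one in compound 2. For the compounds shown here, this does not show that the change would carry over to a third core, since the reading rests on only two matched pairs, and neither pair isolates the effect of position by placing the methoxy at two sites on one core.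

The compounds shown leave open whether a group other than methoxy on the same aromatic carbon, such as a hydroxyl, an amine or a longer chain like ethoxy, would give a step of similar direction and size. They also leave open whether the step would persist with the carbonyl of the shared core replaced, as every compound here keeps that group and carries only methoxy groups on its aromatic rings.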